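Benzyl to 4-chlorophenyl on an aromatic nitrogen

The source may report more compounds than this note shows. Statements on the series, on what has been measured and on what is new or still open speak of the compounds shown alone.

Two cores carry the same pair of side groups. Compound 2 `CCCCCc1ccc(C#Cc2c(-c3ccc(CCCCC)cc3)oc3nc(=O)n(Cc4cn(Cc5ccccc5)nn4)cc23)cc1` and compound 1 `CCCCCc1ccc(C#Cc2c(-c3ccc(CCCCC)cc3)oc3nc(=O)n(Cc4cn(-c5ccc(Cl)cc5)nn4)cc23)cc1` share one core; compound 3 `O=c1nc2oc(CCCCl)cc2cn1Cc1cn(Cc2ccccc2)nn1` and the unmeasured compound 4 `O=c1nc2oc(CCCCl)cc2cn1Cc1cn(-c2ccc(Cl)cc2)nn1` share another, and the difference between the two cores is not broken down here. In a functional assay on HeLa cells (Homo sapiens) for antiproliferative activity, read by MTT assay, with a stated time of 72 h (on this read-out higher numbers stand for weaker inhibition and lower numbers for stronger inhibition), compound 2 gives 73000 nM. For compound 1 the value in this assay is a limit of the assay, > 100000 nM. On these data alone, the change between them, (4-chlorophenyl in place of benzyl on an aromatic nitrogen), is read as an at least 1.3-fold higher number from compound 2 to compound 1 (0.13 log units; that floor lies within the scatter); because the value of compound 1 sits at the limit of > 100000 nM in this assay, at which 1 of the 3 values shown sits, the true size of that step stays open. Compound 3 gives 9580 nM in this assay, the lowest number among the measured compounds, with compound 2 well apart from it. Compound 4 repeats the same change on the core of compound 3: 4-chlorophenyl in place of benzyl on an aromatic nitrogen. The place of the change is described in the same words for both pairs, so it is taken as the same change. Given that an at least 1.3-fold higher number from compound 2 to compound 1 (0.13 log units; that floor lies within the scatter) reaches only a floor, the expected step is set as a modest loss, a 1.6-fold higher number from compound 3 to compound 4 (0.19 log units; within the scatter), with a wide range around it. The estimate for compound 4 in this assay is 15000 nM, expected to lie between 6000 nM and 40000 nM.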

Compound 4, half-maximal inhibitory concentration: 60200 nM
The estimate for compound 4 lay 4.0-fold (0.60 log units) below the measured number; measured number outside the range, above it.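

On the core of compound 3, 4-chlorophenyl in place of benzyl on an aromatic nitrogen gives a clear loss in this assay, read as a 6.3-fold higher number from compound 3 to compound 4 (0.80 log units; beyond the scatter). Set beside the other core, this does not yet fix how far the change carries, and the two steps cannot be called equal or different: the same change on two cores in this assay, an at least 1.3-fold higher number (0.13 log units; that floor lies within the scatter) from compound 2 to compound 1 and a 6.3-fold higher number (0.80 log units; beyond the scatter) from compound 3 to compound 4; the limit leaves it open whether they differ. Compound 1 gives > 100000 nM, which is a limit of the assay and not a number, and the floor of its step alone does not establish a loss on that core, so the result shows a real loss on one core and, on the other, only a step open in size: the limit of > 100000 nM in this assay, at which 1 of the 4 values shown sits.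

The compounds shown do not separate the part played by the chlorine from the part played by the carbon link that benzyl has and 4-chlorophenyl lacks, and plain phenyl or 4-chlorobenzyl on the same aromatic nitrogen would bear on that split. Also open, on these data alone, is how a more distant replacement on that nitrogen, such as a chain ending in an amine or a carboxylic acid, would read on either core.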